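Removing the Iodine: Expected Cytotoxicity of Compound 3

This account rests on a few compounds, and the source may have more. Where it says the series, first, only, none or still open, it means among the compounds named here.

Compound 1 `CCc1ccc(-c2nc3c(c(C)nn3-c3ccccc3)c(-c3ccccc3C#N)c2C#N)cc1` and compound 2 `CCc1ccc(-c2nc3c(c(C)nn3-c3ccccc3)c(-c3ccccc3I)c2C#N)cc1` share one core and differ in a single group on an aromatic ring: a step that the two limits leave unreadable from compound 1 to compound 2. In an ADME assay on BJ cells (Homo sapiens) for cytotoxicity, with a stated time of 72 h (on this read-out lower numbers stand for an effect already at smaller amounts and higher numbers for an effect only at larger amounts of compound), compound 1 gives a limit of > 20000 nM. In this assay compound 2 likewise gives a limit of > 20000 nM. Compound 2 thus stands at the limit that both measured values share (the limit of > 20000 nM in this assay, at which 2 of the 2 values shown sit). Compound 3 `CCc1ccc(-c2nc3c(c(C)nn3-c3ccccc3)c(-c3ccccc3)c2C#N)cc1` has not yet been measured; it differs from compound 2 as follows: hydrogen in place of iodo on an aromatic carbon. Among the compounds with values here, the one measured step concerns the same aromatic carbon, yet it was not readable, so it gives no expectation of a step in this assay beyond the scatter in either direction. Compound 3 is therefore expected to sit at a similar level, with an estimated 30000 nM in this assay, between 12000 nM and 100000 nM. The step from compound 2 to compound 3 is estimated as a step that the limit leaves unreadable from compound 2 to compound 3.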

Compound 3, half-maximal effective concentration: > 20000 nM
Compound 3: only a limit was reported; the forecaster's own chance of this, stated with the estimate: 85%; the middle value does not contradict the limit.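

Compound 2 and compound 3 give no readable step in this assay, and neither do compound 1 and compound 3, since all three values are limits and not numbers: the limit of > 20000 nM in this assay, at which 3 of the 3 values shown sit.

The compounds shown leave open what amount of each compound, if any, would produce half-maximal cytotoxicity, and whether the changes on the aromatic carbon alter it.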